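Swapping the imidazoline of compound 3 for an imidazolylthio group

The source may hold more compounds than are shown below. What is called first, only, known or untested is meant among the compounds shown, and "the series" means these compounds.

Of the compounds shown here, three have been measured in an assay on isolated protein for binding affinity to Alpha-1D adrenergic receptor (Rattus norvegicus), read by radioligand binding; on this read-out higher numbers stand for weaker inhibition and lower numbers for stronger inhibition. Compound 1 `CC(c1cccc(NS(C)(=O)=O)c1)c1c[nH]cn1` gives 692 nM and compound 3 `CCS(=O)(=O)Nc1cccc(NC2=NCCN2)c1` gives 355 nM, two numbers that lie within the usual scatter of one another. Compound 2 `CCS(=O)(=O)Nc1cccc(-c2c[nH]cn2)c1` returns only a limit of the assay, < 10000 nM. The single step between neighbours that differ in one place, a step that the limit leaves unreadable from compound 2 to compound 3, therefore cannot be read, as shown by the limit of < 10000 nM in this assay, at which 1 of the 3 values shown sits.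

Compound 4 `CCS(=O)(=O)Nc1cccc(Sc2c[nH]cn2)c1` is compound 3 with one change: a group of 6 heavy atoms (3 carbon, 2 nitrogen, 1 sulfur; one five-membered aromatic ring with 2 hetero atoms) in place of a group of 6 heavy atoms (3 carbon, 3 nitrogen; one five-membered non-aromatic ring with 2 hetero atoms), on an aromatic carbon. Within the data shown here, no measured step bears on this change in a readable way, since the only step that exchanges the aromatic ring for the non-aromatic one sits on a limit. Compound 1, carrying the aromatic ring on a one-carbon linker, gives 692 nM, which is the nearest guide. Compound 4 is therefore expected to land near the weaker end of the measured numbers, with a 4.2-fold higher number from compound 3 to compound 4 (0.63 log units; beyond the scatter) from compound 3. The estimate for compound 4 is 1500 nM, within 300 nM to 8000 nM.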

Compound 4, inhibition constant: < 10000 nM
Compound 4: no number, only a limit; the forecaster's own chance of this, stated with the estimate: 20%; the middle value does not contradict the limit.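

Compound 4 returns only a limit, so its steps from compound 3 and from compound 2 cannot be read: the limit of < 10000 nM in this assay, at which 2 of the 4 values shown sit.

The compounds shown leave open how far compound 4 lies from compound 3 in this assay, and whether (1H-imidazol-4-yl)sulfanyl differs at all from the 1H-imidazol-4-yl of compound 2.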